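The source may hold more compounds than are shown below. What is called first, only, known or untested is meant among the compounds shown, and "the series" means these compounds.

Measured compounds:
Compound 1, `CCc1ccc(NC(=O)Nc2cccc(CNc3nccnc3Cl)c2)c(CC)c1`, gives 6130 nM in a functional assay on MGC-803 cells (Homo sapiens) for antiproliferative activity, read by MTT assay, with a stated time of 48 h; a higher number here means a weaker inhibitor, a lower number a stronger inhibitor.
Compound 2, `CC(C)(C)c1ccc(NC(=O)Nc2cccc(CNc3nccnc3Cl)c2)cc1`, gives 4820 nM in this assay.

Compound 2 has the lowest of the two numbers, but compound 1 lies within the scatter of it, so no order between the two can be claimed; both sit in the same range. Compound 3, `COc1ccc(NC(=O)Nc2cccc(CNc3nccnc3Cl)c2)cc1`, has not yet been measured in this assay. It differs from compound 2 at a single place: methoxy in place of tert-butyl on an aromatic carbon. Among the measured compounds shown here, no step between measured compounds covers this change, so there is no measured guide to its size. The two measured compounds each carry a group on this aromatic carbon and give numbers close to one another, which gives no sign that the group at this position moves the number strongly. For compound 3 the expected step is a 1.3-fold higher number from compound 2 to compound 3 (0.13 log units; within the scatter), small and toward a weaker number if it reaches beyond the scatter at all. The estimate for compound 3 in this assay is 6500 nM, with a range from 2500 nM to 17000 nM.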

Compound 3, half-maximal inhibitory concentration: 9240 nM
The estimate for compound 3 lay 1.4-fold (0.15 log units) below the measured number; the measured number falls inside the stated range.
By their numbers in this assay, from the lowest: compounds 2, 1 and 3 (each within the scatter of the next).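

Among the compounds shown here, exchanging tert-butyl for methoxy on this aromatic carbon provides the only step between compounds differing in one place in this assay, and it amounts to a 1.9-fold higher number from compound 2 to compound 3 (0.28 log units; within the scatter). The exchange therefore stays within the scatter, even though the entering group has fewer heavy atoms than the leaving group, contains oxygen and adds a hydrogen-bond acceptor. This single pair gives no measured sign that the number responds to the exchange, although it cannot show that the position is insensitive in general, and nothing available gives a measured reason for the result or links it to a property of either group.

The compounds shown leave open whether any group on this carbon can produce a step beyond the scatter, as a primary amine, a carboxylic acid or a longer chain such as n-hexyl would test. They also leave open how much each ethyl group of compound 1 contributes, and that compound's step to either of the other two compounds cannot be read, as it differs from them in more than one place.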